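Methoxy count on the aryl ring of the carbonyl

The source may report more compounds than this note shows. Statements on the series, on what has been measured and on what is new or still open speak of the compounds shown alone.

Going by the values given here, compound 1 `COc1ccc(C(=O)c2ccc3c(ccn3Cc3ccc(C(=O)NO)cc3)c2)cc1OC` carries the 3,4-dimethoxyphenyl on the carbonyl carbon; in an assay on isolated protein for inhibition of protein deacetylase HDAC6 (Homo sapiens) (a lower number here means a stronger inhibitor, a higher number a weaker inhibitor), compound 1 gives 15.5 nM, the higher of the two numbers so far. Compound 2 `Cc1ccc(C(=O)c2ccc3c(ccn3Cc3ccc(C(=O)NO)cc3)c2)cc1` gives 11.9 nM, and the step of a 1.3-fold lower number from compound 1 to compound 2 (0.11 log units; within the scatter) stays within the scatter. Compound 3 `COc1cc(C(=O)c2ccc3c(ccn3Cc3ccc(C(=O)NO)cc3)c2)cc(OC)c1OC` differs from compound 1 by methoxy in place of hydrogen on an aromatic carbon. Among the compounds with values here, only the step from compound 1 to compound 2 bears on this change, and it showed no movement beyond the scatter on altering the aryl substitution, so the expected step is a 1.0-fold lower number from compound 1 to compound 3 (0.01 log units; within the scatter). Compound 3 is estimated at 15 nM, with a range of 6 nM to 40 nM.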

Compound 3, half-maximal inhibitory concentration: 1540 nM
Estimate against measurement, compound 3: 100-fold (2.01 log units) below, outside the stated range (above it).
By their numbers in this assay, from the lowest: compounds 2 and 1 (each within the scatter of the next); then compound 3.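

In this assay, methoxy in place of hydrogen on an aromatic carbon, ortho to a methoxy group, gives a 99-fold higher number from compound 1 to compound 3 (2.00 log units; beyond the scatter). The aryl ring on the carbonyl is therefore not indifferent to substitution, as the step of a 1.3-fold lower number from compound 1 to compound 2 (0.11 log units; within the scatter) alone had left possible: this one added group costs far more than that exchange did. Nothing at hand bears on the cause of this loss. As far as these compounds go, whether the loss depends on the size of the entering group remains open, and a hydroxyl or a fluorine at this place would test that. Also open, from the compounds shown here alone, is whether the loss needs the other two methoxy groups to be present.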